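Swapping the ring methoxy of compound 3 for isopropyl

A few compounds are considered here, and "the series" means these few. Any claim that something is new, unique, unknown or untested is made for them only; others in the source may bear on it.

Measured compounds:
- compound 1, `CCCCCCCC/C=C/CCCCCCCC(=O)Nc1ccccc1C(C)C`: 600 nM
- compound 2, `CCCCCCCC/C=C/CCCCCCCC(=O)Nc1ccc(OC)cc1OC`: 3000 nM
- compound 3, `CCCCCCCC/C=C/CCCCCCCC(=O)Nc1c(C)cccc1OC`: 20 nM

All three compounds share the same long unsaturated fatty-acid amide and differ only in the substitution of the aromatic ring on the amide nitrogen. In an assay on microsomes from intestine for inhibition of acyl-CoA:cholesterol acyltransferase (Oryctolagus cuniculus) (on this read-out higher numbers stand for weaker inhibition and lower numbers for stronger inhibition), compound 3 gives the lowest number of the three, with a 30-fold lower number from compound 1 to compound 3 (1.48 log units; beyond the scatter) and a 150-fold lower number from compound 2 to compound 3 (2.18 log units; beyond the scatter). Compound 2 sits at the weak end, as shown by a 5.0-fold higher number from compound 1 to compound 2 (0.70 log units; beyond the scatter).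

Compound 4, `CCCCCCCC/C=C/CCCCCCCC(=O)Nc1c(C)cccc1C(C)C`, is not yet measured. It differs from compound 3 in one place: isopropyl in place of methoxy on an aromatic carbon. Compound 4 keeps the methyl of compound 3 and combines it with the isopropyl seen in compound 1. For the measured compounds named here, the only measured step that touches isopropyl is the one from compound 1 to compound 3, which changes two groups at once, so the contribution of isopropyl alone cannot be separated from that of the added methyl. Nothing measured isolates the methoxy-to-isopropyl swap.

Given that compound 4 retains the two-group substitution pattern of compound 3, the expected change in this assay is small, a 2.0-fold higher number from compound 3 to compound 4 (0.30 log units; within the scatter), and compound 4 is estimated at 40 nM, with a range from 8 nM to 200 nM.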

Compound 4, half-maximal inhibitory concentration: 23 nM
The estimate for compound 4 lay 1.7-fold (0.24 log units) above the measured number; low and high end bracket the measured number.
By their numbers in this assay, from the lowest: compounds 3 and 4 (each within the scatter of the next); then compound 1; then compound 2.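

In this assay, for the compounds shown here, isopropyl in place of methoxy on this aromatic carbon gives a step within the scatter (a 1.2-fold higher number from compound 3 to compound 4 (0.06 log units; within the scatter)), so the oxygen and the one hydrogen-bond acceptor counted on methoxy can be lost here without a change that can be told from the scatter, something no earlier pair could show. Compound 4 also isolates the methyl, which the earlier step between the two compounds with a methyl-free and a methyl-bearing ring could not do, since two groups changed there: methyl in place of hydrogen on an aromatic carbon gives a large step (a 26-fold lower number from compound 1 to compound 4 (1.42 log units; beyond the scatter)). The swap of the whole group on the amide nitrogen is large as well (a 130-fold lower number from compound 2 to compound 4 (2.12 log units; beyond the scatter)), but it alters several groups at once, and nothing measured here gives a reason for any of these steps.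

Going by these compounds, it remains open whether this place would accept other groups equally, such as a tert-butyl, a chlorine or an amine. The shared core also leaves open what plain hydrogen would do at this place while the methyl stays.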